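The source may hold more compounds than are shown below. What is called first, only, known or untested is meant among the compounds shown, and "the series" means these compounds.

In an assay on isolated protein for inhibition of receptor-type tyrosine-protein phosphatase C (Homo sapiens), read by spectrophotometry (a lower number here means a stronger inhibitor, a higher number a weaker inhibitor), compound 1 `CCN(CC)C(=O)COc1ccc2cc(C(O)(C(F)(F)F)C(F)(F)F)c(O)cc2c1` gives > 20000 nM, which is a limit of the assay rather than a number. Compound 2 `Oc1c(-c2ccccc2)cccc1C(O)(C(F)(F)F)C(F)(F)F` gives 157000 nM in this assay. Compound 1 thus stands at the limit of > 20000 nM in this assay, at which 1 of the 2 values shown sits, and nothing more of its position is known. Compound 3 `CCCNC(=O)COc1ccc2cc(C(O)(C(F)(F)F)C(F)(F)F)c(O)cc2c1` differs from compound 1 by propylamino in place of diethylamino on a carbonyl carbon. Among the measured compounds shown here, no step between measured compounds exists for this kind of change; the expectation in this assay is therefore no shift beyond the usual scatter. Compound 3 is estimated at 30000 nM in this assay, within 10000 nM to 150000 nM, an expected step that the limit leaves unreadable from compound 1 to compound 3.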

Compound 3, half-maximal inhibitory concentration: > 20000 nM
Compound 3 was reported as a limit (the forecaster's own chance of this, stated with the estimate: 60%); the middle value is on the limit's open side.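

Compound 1 and compound 3 are both reported only as limits in this assay, so no step between them can be read: the limit of > 20000 nM in this assay, at which 2 of the 3 values shown sit.

Going by these compounds, whether propylamino in place of diethylamino on the carbonyl carbon shifts inhibition at all remains open.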